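This account rests on a few compounds, and the source may have more. Where it says the series, first, only, none or still open, it means among the compounds named here.

Of the compounds shown here, three have been measured in an assay on HEK293 cells for inhibition of Monoacylglycerol lipase ABHD6 (Homo sapiens), read by fluorescence; on this read-out lower numbers stand for stronger inhibition and higher numbers for weaker inhibition. Compound 1 `O=C(N1CCC=C[C@H]1Cc1ccccc1)n1cc(-c2ccc(-c3ccccc3)cc2)nn1` gives 25.1 nM in this assay, compound 2 `O=C(N1C[C@H](O)C=C[C@@H]1COCc1ccccc1)n1cc(-c2ccc(-c3ccccc3)cc2)nn1` gives 5.01 nM, and compound 3 `O=C(N1CCC=C[C@@H]1COCc1ccccc1)n1cc(-c2ccccc2)nn1` gives 158 nM. Compound 3 therefore stands at the highest number of the three, beyond the scatter from compound 1 and further still beyond the scatter from compound 2, which shows the lowest number of the set.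

Compound 4 `O=C(N1CCC=C[C@@H]1COCc1ccccc1)n1cc(-c2ccc(Oc3ccccc3)cc2)nn1` differs from compound 3 by phenoxy in place of hydrogen on an aromatic carbon. For the measured compounds named here, no pair of measured compounds shows this exact change, so the size of the step can only be inferred. Going by the values given here, compound 3 is the one compound whose triazole substituent carries a single aromatic ring, while compounds 1 and 2, each bearing a further ring on that aromatic group, return lower numbers. Compound 4 is expected to move in the same direction, with a step beyond the scatter towards stronger inhibition. The step from compound 3 to compound 4 is estimated as a 9.9-fold lower number from compound 3 to compound 4 (0.99 log units; beyond the scatter). Compound 4 is expected to give 16 nM in this assay, within a range of 4 nM to 63 nM.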

Compound 4, half-maximal inhibitory concentration: 6.31 nM
Compound 4: the middle estimate sits 2.5-fold (0.40 log units) above what was measured; the measured number falls inside the stated range.
By their numbers in this assay, from the lowest: compounds 2 and 4 (each within the scatter of the next); then compound 1; then compound 3.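

For the compounds shown here, this is the first change in the set that can be read at a single place: in this assay, phenoxy in place of hydrogen on an aromatic carbon, para to a large group, gives a 25-fold lower number from compound 3 to compound 4 (1.40 log units; beyond the scatter), a large step beyond the scatter. The position therefore accepts a group carrying a further aromatic ring, and on this core that addition comes with much stronger inhibition. Nothing measured here accounts for the size of the step.

The compounds shown leave open whether the oxygen of phenoxy matters, or whether phenyl, benzyl or a smaller methoxy at the same place on this core would give a similar number. They also leave open how an amine or a carboxylic acid on the added ring would read.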